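The source may hold more compounds than are shown below. What is called first, only, known or untested is meant among the compounds shown, and "the series" means these compounds.

Measured so far:
compound 1 `COc1ncccc1C(=O)NCCC1CCN(S(=O)(=O)NC(=O)NC2CCCCC2)CC1`: 33%
compound 2 `Cc1ncccc1C(=O)NCCC1CCN(S(=O)(=O)NC(=O)NC2CCCCC2)CC1`: 16%

In a functional assay on the whole organism (blood) with Rattus norvegicus as the target, with stated times of 24 h and 1 h, at a dose of 5 mg/kg by the intraperitoneal route (on this read-out higher numbers stand for a stronger effect at the one dose given and lower numbers for a weaker effect), compound 1 gives 33% and compound 2 gives 16%. Going by the values given here, compound 2 stands lowest of the two numbers; the only measured step is a number 17 percentage points lower from compound 1 to compound 2 (beyond the scatter), brought by methyl in place of methoxy on an aromatic carbon. Compound 3 `O=C(NC1CCCCC1)NS(=O)(=O)N1CCC(CCNC(=O)c2ccc3ccccc3n2)CC1` is not yet measured. (quinolin-2-yl in place of 2-methylpyridin-3-yl on a carbonyl carbon). The measured step of a number 17 percentage points lower from compound 1 to compound 2 (beyond the scatter) exchanges a substituent on the aromatic ring rather than the ring itself, so it bears only weakly on this change, though it shows that alterations at this end of the molecule can move the read-out by a modest amount. No direction can be read from the two numbers; a step of that size either way remains plausible. Compound 3 is therefore estimated at 25%, with a range from 5% to 50%. The expected step is a number 9 percentage points higher from compound 2 to compound 3 (within the scatter), within wide uncertainty.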

Compound 3, a percentage reported as activity, at one dose (the size of the read-out at that dose, not a potency): 11%
Estimate against measurement, compound 3: 14 percentage points above; low and high end bracket the measured number.
By their numbers in this assay, from the lowest: compounds 3 and 2 (each within the scatter of the next); then compound 1.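

In this assay, replacing the whole aromatic group on the carbonyl carbon, and not just a substituent on it, gives a number 5 percentage points lower from compound 2 to compound 3 (within the scatter), so the added carbon-only aromatic ring of quinolin-2-yl does not separate compound 3 from compound 2. Against 2-methoxypyridin-3-yl, the same exchange gives a number 22 percentage points lower from compound 1 to compound 3 (beyond the scatter). Of the three groups at this position, only the 2-methoxypyridin-3-yl of compound 1 stands apart from the other two, and its numbers are beyond the scatter of both. No available data explain these differences.

Still open, from the compounds shown here alone, is whether the methoxy group itself carries the higher number, which an ethoxy or a dimethylamino group on the same pyridine ring would test. The compounds shown also leave open how a plain phenyl or a methoxy-bearing quinolin-2-yl would read at this position.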